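The source may report more compounds than this note shows. Statements on the series, on what has been measured and on what is new or still open speak of the compounds shown alone.

Measured in a functional assay on THP-1 cells (Homo sapiens) for inhibition, read by sulforhodamine B assay, with a stated time of 48 h, tested at 50 uM; a lower number here means less inhibition of growth, a higher number more inhibition of growth at the concentration tested:
- compound 1 `COc1cc(/C=C/C(=O)/C=C/c2cccc3ccccc23)ccc1OCc1cn(CCOc2cc(=O)oc3ccccc23)nn1`: 89%
- compound 2 `COc1ccccc1/C=C/C(=O)/C=C/c1ccc(OCc2cn(CCCOc3cc(=O)oc4ccccc34)nn2)c(OC)c1`: 50%

Of these two numbers, compound 2 at 50% is the lower, and the gap to compound 1 lies beyond the scatter. The two compounds differ in more than one place, so this gap cannot be assigned to any single change and does not size the change considered here.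

The next compound is compound 3 `COc1cc(/C=C/C(=O)/C=C/c2ccccc2)ccc1OCc1cn(CCCOc2cc(=O)oc3ccccc23)nn1`, reached from compound 2 by one change: hydrogen in place of methoxy on an aromatic carbon. Hydrogen stands in place of methoxy on an aromatic carbon, ortho to a large group, turning 2-methoxyphenyl into phenyl. Among the measured compounds shown here, the series holds no measured step for this change, or for any other single change, so the expectation is weakly grounded. On these data alone, no step beyond the scatter is expected in this assay, and the direction remains open. The estimated step is a number 2 percentage points higher from compound 2 to compound 3 (within the scatter). For compound 3 the expected value is 52%, with an estimated range from 32% to 72%.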

Compound 3, percent growth inhibition at one concentration: 48%
The estimate for compound 3 lay 4 percentage points above the measured number; measured number inside the range.
By their numbers in this assay, from the lowest: compounds 3 and 2 (each within the scatter of the next); then compound 1.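

In this assay, among the compounds shown here, the replacement of methoxy by hydrogen on an aromatic carbon, ortho to a large group, gives the first single-change step: a number 2 percentage points lower from compound 2 to compound 3 (within the scatter). At this place, 2-methoxyphenyl and phenyl are therefore not told apart by this read-out at the one concentration tested, so the growth inhibition seen for compound 2 does not depend measurably on this methoxy. Nothing on hand bears on why the two compounds read alike.

Compound 1 differs from compound 2 and from compound 3 in more than one place, so its gaps to them cannot be read as steps, and neither the naphthalene-bearing end of compound 1 nor its linking chain can yet be sized alone. Still open, on these data alone, is whether a different group at this place, such as an amine or a carboxylic acid, would move the number beyond the scatter, and whether the flat result for methoxy and hydrogen would hold at a lower concentration or in a full dose-response curve.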